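Amide nitrogen substituents on a shared core

The source may report more compounds than this note shows. Statements on the series, on what has been measured and on what is new or still open speak of the compounds shown alone.

Measured so far:
compound 1 `O=C(Nc1ccccn1)c1c(O)c2cccnc2n(-c2ccccc2)c1=O` — 14.6%
compound 2 `O=C(NCc1ccccc1)c1c(O)c2cccnc2n(-c2ccccc2)c1=O` — 11.3%
compound 3 `O=C(Nc1ccc(Cl)cc1)c1c(O)c2cccnc2n(-c2ccccc2)c1=O` — 2.5%

In a functional assay on the whole organism for inhibition, with Rattus norvegicus as the target, read by cytopathic effect and paw edema, at a dose of 100 mg/kg by the oral route (a higher number here means more inhibition at the dose given (going by the name of the read-out), a lower number less inhibition), compound 1 gives 14.6%, the highest of the three numbers. The step of a number 3.3 percentage points lower from compound 1 to compound 2 (within the scatter) stays within the scatter, whereas a number 12.1 percentage points lower from compound 1 to compound 3 (beyond the scatter) goes beyond it. Compound 4 `O=C(Nc1ccncc1)c1c(O)c2cccnc2n(-c2ccccc2)c1=O` differs from compound 1 by pyridin-4-yl in place of pyridin-2-yl on an amide-type nitrogen. Among the compounds with values here, no measured step exchanges one pyridyl for another, so the bearing of the existing steps is indirect: both steps away from compound 1 replace pyridin-2-yl and both run lower, at most modestly. The change to compound 4 keeps the same atoms, so in this assay a small downward drift, most likely not beyond the scatter, is expected, a number 3.6 percentage points lower from compound 1 to compound 4 (within the scatter). Compound 4 is estimated to give 11%, with a range from 0% to 24%.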

Compound 4, a percentage reported as inhibition, in the whole organism at one dose (the size of the read-out at that dose, not a potency): 24.3%
Compound 4: middle estimate off by 13.3 percentage points, on the low side; the measured number lies above the stated range.
By their numbers in this assay, from the lowest: compounds 3, 2, 1 and 4 (each within the scatter of the next, the first and the last beyond it).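

Within the data shown here, the first exchange of one pyridyl for another at this amide-type nitrogen, in this assay, gives a step within the scatter (a number 9.7 percentage points higher from compound 1 to compound 4 (within the scatter)), so the two attachment patterns are not separated here. Pyridin-4-yl does separate from both non-pyridyl groups (a number 21.8 percentage points higher from compound 3 to compound 4 (beyond the scatter); a number 13 percentage points higher from compound 2 to compound 4 (beyond the scatter)), whereas pyridin-2-yl separates only from 4-chlorophenyl, not from benzyl. No available evidence bears on the origin of these differences.

Still open, as far as these compounds go, is where pyridin-3-yl would fall at this position. Also open, from the compounds shown here alone, is whether an amino group on the pyridin-4-yl ring would preserve the separation from benzyl and 4-chlorophenyl.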